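Trimming the side chain of a lipid-bearing aminoglycoside fragment

The source may hold more compounds than are shown below. What is called first, only, known or untested is meant among the compounds shown, and "the series" means these compounds.

Compound 1 `CCCCCCCCCO[C@@H]1[C@@H](N)[C@@H](O[C@H]2[C@H](O)[C@@H](O)[C@H](N)C[C@@H]2N)O[C@H](CN)[C@H]1OCCCCCCCCC`: 82.7%
Compound 2 `CCCCCCCCCO[C@@H]1[C@@H](N)[C@@H](OCC(O)CNCCO)O[C@H](CN)[C@H]1OCCCCCCCCC`: 99.1%
Compound 3 `CCCCCCCCCO[C@@H]1[C@@H](N)[C@@H](OCC(O)CNCCCN)O[C@H](CN)[C@H]1OCCCCCCCCC`: 101%

In a toxicity assay on the whole organism (J774 cells) for cytotoxicity, with Mus musculus as the target, read by MTT assay, with a stated time of 24 h, tested at 10 uM (a lower number here means a stronger effect, a higher number a weaker effect of the compound at the concentration tested), compound 3 gives 101%. The step of a number 18.3 percentage points higher from compound 1 to compound 3 (beyond the scatter) lies beyond the scatter, whereas the step of a number 1.9 percentage points higher from compound 2 to compound 3 (within the scatter) does not, so compound 3 and compound 2 cannot be told apart here. Compound 4 `CCCCCCCCCO[C@@H]1[C@@H](N)[C@@H](OC[C@@H](O)CN)O[C@H](CN)[C@H]1OCCCCCCCCC` carries the change (2-amino-1-hydroxyethyl in place of 2-((3-aminopropyl)amino)-1-hydroxyethyl on a saturated chain carbon bound to an oxygen on a saturated carbon). Within the data shown here, no measured step cuts this chain back; the nearest evidence is a number 1.9 percentage points higher from compound 2 to compound 3 (within the scatter), which shows that swapping an end group on this chain left the number unchanged. With both open-chain compounds sitting close together, no step beyond the scatter is expected, a number 3 percentage points lower from compound 3 to compound 4 (within the scatter). Compound 4 is therefore estimated at 98%, within 86% to 108%.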

Compound 4, a percentage reported as activity, at one concentration (the size of the read-out at that concentration, not a potency): 85.1%
The estimate for compound 4 lay 12.9 percentage points above the measured number; the measured number lies below the stated range.
By their numbers in this assay, from the lowest: compounds 1 and 4 (each within the scatter of the next); then compounds 2 and 3 (each within the scatter of the next).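

Shortening the side chain does register in this assay, unlike the end-group swap between compound 2 and compound 3: the step to 3-amino-2-hydroxypropyl is (a number 15.9 percentage points lower from compound 3 to compound 4 (beyond the scatter)) and (a number 14 percentage points lower from compound 2 to compound 4 (beyond the scatter)). The short open chain also cannot be told apart from the 4,6-diamino-2,3-dihydroxycyclohexyl group (a number 2.4 percentage points higher from compound 1 to compound 4 (within the scatter)), so a ring is not needed at this position for a number in this range. Nothing on hand explains these steps.

Still open, as far as these compounds go, is how a chain of intermediate length would read here, or a carboxylic acid in place of the end amine.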